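Moving the Methyl Around the Sulfonyl Ring

The compounds below may be only part of what the source reports. "The series", "measured", "known", "first", "only" and "open" are said of these compounds alone.

Of the compounds shown here, three built on one shared core have been tested in a functional assay on MCF7 cells (Homo sapiens) for antiproliferative activity, read by MTT assay, with a stated time of 48 h; a lower number here means a stronger inhibitor, a higher number a weaker inhibitor. Compound 1 `O=C(/C=C/c1cccc(NC(=O)c2ccccc2Br)c1)c1nc2ccccc2[nH]1` gives 4520 nM. Compound 2 `O=C(/C=C/c1cccc(NS(=O)(=O)c2ccc(Cl)cc2)c1)c1nc2ccccc2[nH]1` gives 3820 nM, and the step of a 1.2-fold lower number from compound 1 to compound 2 (0.07 log units; within the scatter) stays within the scatter. Compound 3 `Cc1cccc(S(=O)(=O)Nc2cccc(/C=C/C(=O)c3nc4ccccc4[nH]3)c2)c1` gives 886 nM, the lowest of the three numbers; the steps of a 5.1-fold lower number from compound 1 to compound 3 (0.71 log units; beyond the scatter) and a 4.3-fold lower number from compound 2 to compound 3 (0.63 log units; beyond the scatter) both run beyond the scatter, so compound 3 stands as the strongest inhibitor of the three measured.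

Compound 4 `Cc1ccc(S(=O)(=O)Nc2cccc(/C=C/C(=O)c3nc4ccccc4[nH]3)c2)cc1` has not yet been measured. It differs from compound 3 in a single respect: 4-methylphenyl in place of 3-methylphenyl on a sulfonyl sulfur. Going by the values given here, the only measured step that touches the ring on the sulfonyl sulfur is a 4.3-fold lower number from compound 2 to compound 3 (0.63 log units; beyond the scatter), which exchanged the substituent and its position at once, so no measured pair isolates the position alone. That step was modest, and the present change keeps the same atoms, so a shift of similar or smaller size is the most the data support, with no clear sign of direction. The step from compound 3 to compound 4 is therefore expected to be a 1.5-fold higher number from compound 3 to compound 4 (0.17 log units; within the scatter), likely near the edge of the scatter. For compound 4 in this assay the estimated value is 1300 nM, with an expected range from 500 nM to 3400 nM.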

Compound 4, half-maximal inhibitory concentration: 3220 nM
For compound 4 the middle estimate is 2.5-fold (0.39 log units) below the measured one; measured number inside the range.
By their numbers in this assay, from the lowest: compound 3; then compounds 4, 2 and 1 (each within the scatter of the next).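

The methyl's position on the ring on the sulfonyl sulfur can now be read apart from the identity of the substituent: 3-methylphenyl giving way to 4-methylphenyl, with the same atoms joined differently, brings a 3.6-fold higher number from compound 3 to compound 4 (0.56 log units; beyond the scatter) in this assay, a step beyond the scatter. Methyl in place of chloro on an aromatic carbon gives a 1.2-fold lower number from compound 2 to compound 4 (0.07 log units; within the scatter), and (4-methylphenyl)sulfonyl in place of (2-bromophenyl)carbonyl gives a 1.4-fold lower number from compound 1 to compound 4 (0.15 log units; within the scatter), both within the scatter, so among these compounds neither the methyl nor the sulfonyl alone goes with the low number; only the 3-methylphenyl group of compound 3 does. No measurement shown explains why the position of the methyl matters here.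

From the compounds shown here alone, it remains open whether a 3-chlorophenyl, a 3-methoxyphenyl or a 2-methylphenyl group on the sulfonyl sulfur would match compound 3 or fall with compound 4. Also open, going by these compounds, is whether a 3-methylphenyl group on a carbonyl in place of the sulfonyl would show the same difference between the two methyl positions.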